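Fluoro to Trifluoromethyl at the Same Aromatic Position

The source may report more compounds than this note shows. Statements on the series, on what has been measured and on what is new or still open speak of the compounds shown alone.

Compound 1 `Cc1ccc(Nc2cncc(N3CC4CC(C3)N4)c2)cc1`: 1.4 nM
Compound 2 `O=[N+]([O-])c1ccc(Nc2cncc(N3CC4CC(C3)N4)c2)cc1`: 0.684 nM
Compound 3 `Fc1ccc(Nc2cncc(N3CC4CC(C3)N4)c2)cc1`: 1.25 nM

In an assay on HEK293 cells for displacement of a labelled ligand from Neuronal acetylcholine receptor; alpha3/beta4 (Homo sapiens) (on this read-out higher numbers stand for weaker inhibition and lower numbers for stronger inhibition), compound 3 gives 1.25 nM, the second highest of the three numbers. Its nearest neighbour is compound 1: a 1.1-fold lower number from compound 1 to compound 3 (0.05 log units; within the scatter). Against compound 2 the gap is a 1.8-fold higher number from compound 2 to compound 3 (0.26 log units; within the scatter), also within the scatter. Compound 4 `FC(F)(F)c1ccc(Nc2cncc(N3CC4CC(C3)N4)c2)cc1` is not yet measured; it differs from compound 3 by trifluoromethyl in place of fluoro on an aromatic carbon. The three measured steps all swap one group at this same place, and the largest of them, a 2.0-fold lower number from compound 1 to compound 2 (0.31 log units; beyond the scatter), is only modest. Among the compounds with values here, no measured step replaces fluoro by trifluoromethyl, so the best guide is that changes here have stayed small. Compound 4 is therefore expected at about 1.3 nM, within 0.5 nM to 3.5 nM, a step of a 1.0-fold higher number from compound 3 to compound 4 (0.02 log units; within the scatter) in this assay.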

Compound 4, inhibition constant: 1.02 nM
Beside the measured number, compound 4's estimate is 1.3-fold (0.11 log units) above it, within the range that was stated.
By their numbers in this assay, from the lowest: compounds 2, 4, 3 and 1 (each within the scatter of the next, the first and the last beyond it).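

Trifluoromethyl has four heavy atoms against the single one of fluoro, yet in this assay the exchange stays within the scatter (a 1.2-fold lower number from compound 3 to compound 4 (0.09 log units; within the scatter)). The same holds against the other two groups (a 1.5-fold higher number from compound 2 to compound 4 (0.17 log units; within the scatter)) and (a 1.4-fold lower number from compound 1 to compound 4 (0.14 log units; within the scatter)), so this position accepts the larger group without a clear shift. No measurement at hand explains why the numbers stay so close.

Still open, as far as these compounds go, is whether an amine, a carboxylic acid or a longer chain at this same place would leave the number equally undisturbed.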